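The compounds below may be only part of what the source reports. "The series", "measured", "known", "first", "only" and "open" are said of these compounds alone.

Working notes on the series. Compound 1 `COc1ccc2c(c1)c(C=O)cn2Cc1cn([C@@H]2O[C@H](COC(C)=O)[C@@H](OC(C)=O)[C@H](OC(C)=O)[C@H]2OC(C)=O)nn1` is read in a functional assay on MCF7 cells (Homo sapiens) for cytotoxicity, read by sulforhodamine B assay, with a stated time of 48 h (on this read-out lower numbers stand for stronger inhibition and higher numbers for weaker inhibition), as a limit of the assay rather than a number, compound 1 giving > 200000 nM. That reading matches (the limit of > 200000 nM in this assay, at which 1 of the 3 values shown sits). Compound 2 `COc1ccc(/C=C2\C(=O)N(Cc3cn([C@@H]4O[C@H](COC(C)=O)[C@@H](OC(C)=O)[C@H](OC(C)=O)[C@H]4OC(C)=O)nn3)c3ccccc32)cc1OC` carries 3,4-dimethoxyphenyl on the double-bonded chain carbon bound to a double-bonded ring carbon, and in this assay compound 2 gives 23500 nM. Compound 3 `CC(=O)OC[C@H]1O[C@@H](n2cc(CN3C(=O)/C(=C/c4cccs4)c4ccccc43)nn2)[C@H](OC(C)=O)[C@@H](OC(C)=O)[C@@H]1OC(C)=O` carries thiophen-2-yl at that place, and in this assay compound 3 gives 28100 nM; the values of compound 2 and compound 3 lie within the scatter of each other, so compound 2 supplies one of two comparable numbers. Compound 4 `CC(=O)OC[C@H]1O[C@@H](n2cc(CN3C(=O)/C(=C\c4ccco4)c4ccccc43)nn2)[C@H](OC(C)=O)[C@@H](OC(C)=O)[C@@H]1OC(C)=O` is not yet measured; it differs from compound 2 by furan-2-yl in place of 3,4-dimethoxyphenyl on a double-bonded chain carbon bound to a double-bonded ring carbon. Among the compounds with values here, no measured step of this kind exists, so the expected step from compound 2 to compound 4 is a 1.1-fold higher number from compound 2 to compound 4 (0.06 log units; within the scatter), none beyond the scatter. Compound 4 is expected to give 27000 nM, with a range from 12000 nM to 60000 nM.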

Compound 4, half-maximal inhibitory concentration: 38200 nM
Estimate against measurement, compound 4: 1.4-fold (0.15 log units) below; low and high end bracket the measured number.
By their numbers in this assay, from the lowest: compounds 2, 3 and 4 (each within the scatter of the next). At a limit, above all of these: compound 1.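

On a double-bonded chain carbon bound to a double-bonded ring carbon, furan-2-yl in place of 3,4-dimethoxyphenyl gives a 1.6-fold higher number from compound 2 to compound 4 (0.21 log units; within the scatter) in this assay. Within the data shown here, this is the first step read at this place, and the smaller five-membered aromatic ring with its single hetero atom takes the place of the six-membered aromatic ring of carbon only without a step beyond the scatter. Nothing shown bears on a cause for this step.

The compounds shown leave open what a non-aromatic group at this place, such as an amine or a carboxylic acid, would give. On these data alone, whether any group here can move the number beyond the scatter also stays open.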